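This account rests on a few compounds, and the source may have more. Where it says the series, first, only, none or still open, it means among the compounds named here.

Measured in a functional assay on A549 cells (Homo sapiens) for inhibition, read by CCK-8 assay, with a stated time of 48 h; a higher number here means a weaker inhibitor, a lower number a stronger inhibitor:
- Compound 1 `COc1cc(-c2ccnc3cc(-c4c[nH]c5ccccc45)nn23)cc(OC)c1OC`: 29 nM
- Compound 2 `COc1cc(-c2ccnc3cc(-c4ccc5c(ccn5C)c4)nn23)cc(OC)c1OC`: 15 nM
- Compound 3 `COc1cc(-c2ccnc3cc(-c4cn(C)c5ccccc45)nn23)cc(OC)c1OC`: 1340 nM

Compound 3 has the highest number of the three, which makes it the weakest inhibitor so far. The evidence is a 46-fold higher number from compound 1 to compound 3 (1.66 log units; beyond the scatter) and an 89-fold higher number from compound 2 to compound 3 (1.95 log units; beyond the scatter). The remaining pair differs only within the scatter: a 1.9-fold lower number from compound 1 to compound 2 (0.29 log units; within the scatter).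

Compound 4 `COc1ccc(-c2cc3nccc(-c4cc(OC)c(OC)c(OC)c4)n3n2)cc1F` changes compound 3 at a single place: 3-fluoro-4-methoxyphenyl in place of 1-methyl-1H-indol-3-yl on an aromatic carbon. Going by the values given here, no measured compound carries 3-fluoro-4-methoxyphenyl, so no step measures this swap directly. The closest guide is an 89-fold higher number from compound 2 to compound 3 (1.95 log units; beyond the scatter), where 1-methyl-1H-indol-3-yl also enters or leaves at this place, and it suggests that this group can cost much in this assay. Removing it may therefore recover much of that loss, though this is uncertain. The expected change is a 13-fold lower number from compound 3 to compound 4 (1.13 log units; beyond the scatter). The estimate for compound 4 is 100 nM, with an expected range of 15 nM to 700 nM.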

Compound 4, half-maximal inhibitory concentration: 545 nM
Estimate against measurement, compound 4: 5.5-fold (0.74 log units) below; the range from low to high includes it.
By their numbers in this assay, from the lowest: compounds 2 and 1 (each within the scatter of the next); then compound 4; then compound 3.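

In this assay, a single six-membered ring of carbon only can replace the two-ring 1-methyl-1H-indol-3-yl at this place, but the gain is modest: a 2.5-fold lower number from compound 3 to compound 4 (0.39 log units; beyond the scatter). The same group falls far short of the other two indolyl groups, with a 36-fold higher number from compound 2 to compound 4 (1.56 log units; beyond the scatter) and a 19-fold higher number from compound 1 to compound 4 (1.27 log units; beyond the scatter). Nothing available explains these differences.

On these data alone, it remains open whether the fluorine or the methoxy of 3-fluoro-4-methoxyphenyl matters more. Also open, as far as these compounds go, is how a plain phenyl or a pyridine ring would compare at this place.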